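Aryl variation on the amide-type nitrogen: estimating compound 4

The compounds below may be only part of what the source reports. "The series", "measured", "known", "first", "only" and "open" are said of these compounds alone.

Measured so far in an assay on isolated protein for inhibition of STE20-like serine/threonine-protein kinase (Homo sapiens), read by thermal shift assay, tested at 10 uM; a lower number here means that the compound stabilises the target less, a higher number that the compound stabilises the target more against heat:
- compound 1 `Cc1ccccc1NC(=O)Nc1cc(C(C)(C)C)nn1-c1ccccc1`: 7.1 degrees C
- compound 2 `CC(C)(C)c1cc(NC(=O)Nc2ccc(F)cc2)n(-c2ccccc2)n1`: 7.4 degrees C
- compound 3 `CC(C)(C)c1cc(NC(=O)Nc2ccc(F)c(F)c2)n(-c2ccccc2)n1`: 5.5 degrees C

Compound 3 carries the lowest of the three numbers in this assay; compound 1 lies above it by a number 1.6 degrees C lower from compound 1 to compound 3 (beyond the scatter) and compound 2 by a number 1.9 degrees C lower from compound 2 to compound 3 (beyond the scatter), both beyond the scatter. Compound 1 and compound 2 differ by a number 0.30 degrees C higher from compound 1 to compound 2 (within the scatter), within the scatter.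

Compound 4 `CC(C)(C)c1cc(NC(=O)Nc2cc(F)cc(F)c2)n(-c2ccccc2)n1` differs from compound 3 only by 3,5-difluorophenyl in place of 3,4-difluorophenyl on an amide-type nitrogen. Among the measured compounds shown here, no measured step moves a fluorine between ring carbons in this way. For the measured compounds named here, the steps that bear on it are a number 1.9 degrees C lower from compound 2 to compound 3 (beyond the scatter), where adding a second fluorine cost a modest amount, and a number 1.6 degrees C lower from compound 1 to compound 3 (beyond the scatter). Going by the values given here, both show that the two-fluorine aryls here sit at the lower end; nothing among the measured compounds separates 3,5-difluorophenyl from 3,4-difluorophenyl. A small step in this assay is therefore expected for compound 4, most likely within or close to the scatter. The estimate for compound 4 is 6 degrees C, with the range 4.5 degrees C to 7.5 degrees C, corresponding to an expected step of a number 0.50 degrees C higher from compound 3 to compound 4 (within the scatter).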

Compound 4, shift of the target's melting temperature: 3 degrees C
Compound 4: the middle estimate sits 3.0 degrees C above what was measured; the whole stated range lies above it.
By their numbers in this assay, from the lowest: compound 4; then compound 3; then compounds 1 and 2 (each within the scatter of the next).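

In this assay the swap of 3,4-difluorophenyl for 3,5-difluorophenyl on the amide-type nitrogen gives a number 2.5 degrees C lower from compound 3 to compound 4 (beyond the scatter) with no change in the atoms of the group, so at this position the arrangement of the two fluorines matters and not just their number. The steps of a number 4.4 degrees C lower from compound 2 to compound 4 (beyond the scatter) and a number 4.1 degrees C lower from compound 1 to compound 4 (beyond the scatter) are larger, which places compound 4 lowest of the four and shows that the two difluorophenyl groups do not share one level. No measurement on hand accounts for this difference between the two arrangements.

The compounds shown leave open whether the low number is tied to fluorine itself or would also appear with chloro, methoxy or nitrile groups on this aryl. They also leave open how a pyridyl ring in place of the phenyl ring would read in this assay.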